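From methyl to isopropoxy on a shared core

The source may report more compounds than this note shows. Statements on the series, on what has been measured and on what is new or still open speak of the compounds shown alone.

Compound 1 `COc1ccc(-c2cc(C(=O)N3CCC4(CC3)CC(=O)c3nn(C(C)(C)C)cc3O4)c3ccccc3n2)cc1`: 2780 nM
Compound 2 `CN1CCN(c2cc(C(=O)N3CCC4(CC3)CC(=O)c3nn(C(C)(C)C)cc3O4)c3ccccc3n2)CC1`: 9550 nM
Compound 3 `Cc1cc(C(=O)N2CCC3(CC2)CC(=O)c2nn(C(C)(C)C)cc2O3)c2ccccc2n1`: 9480 nM

In a functional assay on HepG2 cells (Homo sapiens) for inhibition, read by MTT assay, with a stated time of 72 h (on this read-out higher numbers stand for weaker inhibition and lower numbers for stronger inhibition), compound 3 gives 9480 nM and sits with compound 2, as a 1.0-fold lower number from compound 2 to compound 3 (0.00 log units; within the scatter) shows, while a 3.4-fold higher number from compound 1 to compound 3 (0.53 log units; beyond the scatter) separates it from compound 1. Compound 4 `CC(C)Oc1cc(C(=O)N2CCC3(CC2)CC(=O)c2nn(C(C)(C)C)cc2O3)c2ccccc2n1` has not yet been measured. It carries isopropoxy in place of methyl on an aromatic carbon, next to the ring nitrogen isopropoxy in place of methyl on an aromatic carbon and shares the rest of its structure with compound 3.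

Within the data shown here, all the measured steps involve this same carbon. Exchanging 4-methoxyphenyl for 4-methylpiperazin-1-yl gave a 3.4-fold higher number from compound 1 to compound 2 (0.54 log units; beyond the scatter) and was the same modest size as the change to methyl. Among the measured compounds shown here, no measured compound carries an alkoxy group here, so the evidence for isopropoxy is indirect. The expected change is small, and the estimated step is a 1.4-fold lower number from compound 3 to compound 4 (0.13 log units; within the scatter) in this assay overall. The estimate for compound 4 is 7000 nM, with an expected range from 3000 nM to 16000 nM for repeated measurements.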

Compound 4, half-maximal inhibitory concentration: 3150 nM
Compound 4: the middle estimate sits 2.2-fold (0.35 log units) above what was measured; the measured number falls inside the stated range.
By their numbers in this assay, from the lowest: compounds 1 and 4 (each within the scatter of the next); then compounds 3 and 2 (each within the scatter of the next).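

In this assay isopropoxy on this aromatic carbon separates from methyl (a 3.0-fold lower number from compound 3 to compound 4 (0.48 log units; beyond the scatter)) and from 4-methylpiperazin-1-yl (a 3.0-fold lower number from compound 2 to compound 4 (0.48 log units; beyond the scatter)). It stands level with 4-methoxyphenyl (a 1.1-fold higher number from compound 1 to compound 4 (0.05 log units; within the scatter)), so the position reaches the lowest numbers shown with either of two quite different groups. Isopropoxy has no ring, so a ring on this carbon is not required for such a number, and 4-methylpiperazin-1-yl shows that a ring alone does not bring one.

Nothing in the data accounts for these differences between the groups. Methoxy, ethoxy or isopropyl on this carbon would help show whether the ether oxygen or the branched chain goes with the lower number, and that question remains open.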